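The compounds below may be only part of what the source reports. "The series", "measured", "known", "first", "only" and "open" are said of these compounds alone.

Compound 1 `CC(C)(C)OC(=O)NCCS(=O)(=O)NC(=O)c1ccc(Nc2nc(NC3(c4ccc(Cl)cc4)CC3)nc(OCC(F)(F)F)n2)cc1` is an acylsulfonamide whose sulfonyl sulfur carries a 2-((tert-butoxycarbonyl)amino)ethyl chain. In an ADME assay on microsomes from liver (Rattus norvegicus) for metabolic stability, with a stated time of 10 min (a lower number here means that less of the compound is left, a higher number that more of the compound is left), compound 1 gives 93%. Compound 2 `CC(C)C(=O)NCCS(=O)(=O)NC(=O)c1ccc(Nc2nc(NC3(c4ccc(Cl)cc4)CC3)nc(OCC(F)(F)F)n2)cc1` gives 84%, and compound 3 `O=C(NS(=O)(=O)CCNCc1ccccc1)c1ccc(Nc2nc(NC3(c4ccc(Cl)cc4)CC3)nc(OCC(F)(F)F)n2)cc1` gives 100%; the step of a number 9 percentage points lower from compound 1 to compound 2 (within the scatter) and the step of a number 7 percentage points higher from compound 1 to compound 3 (within the scatter) both leave compound 1 in the same band as its two neighbours, while the step of a number 16 percentage points higher from compound 2 to compound 3 (beyond the scatter) separates compounds 2 and 3 by a modest margin. Compound 4 `Cc1ccccc1S(=O)(=O)NC(=O)c1ccc(Nc2nc(NC3(c4ccc(Cl)cc4)CC3)nc(OCC(F)(F)F)n2)cc1` has not been measured in this assay. It differs from compound 1 as follows: 2-methylphenyl in place of 2-((tert-butoxycarbonyl)amino)ethyl on a sulfonyl sulfur. The measured steps change only the group on the amine nitrogen or the carbonyl carbon of that chain, so none of them tests the present change directly; they show, however, that every variant of this side chain keeps a high fraction of compound after the stated time. Compound 4 is therefore expected to stay in the same high band, with the expected step of a number 5 percentage points lower from compound 1 to compound 4 (within the scatter) not beyond the scatter, and its estimated value is 88% within a range from 72% to 100%.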

Compound 4, percent of the compound remaining: 100%
For compound 4 the middle estimate is 12 percentage points below the measured one; the range from low to high includes it.
By their numbers in this assay, from the lowest: compounds 2, 1, 3 and 4 (each within the scatter of the next, the first and the last beyond it).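

The earlier compounds shown here altered only the end of the chain on the sulfonyl sulfur, whereas compound 4 replaces the entire 2-((tert-butoxycarbonyl)amino)ethyl chain with 2-methylphenyl, a six-membered aromatic ring of carbon only with no hydrogen-bond donors or acceptors. In this assay, this exchange gives a number 7 percentage points higher from compound 1 to compound 4 (within the scatter), and the exchange of the 2-(benzylamino)ethyl chain gives no change at the digits printed from compound 3 to compound 4 (within the scatter), so neither the open chain nor its nitrogen is needed for a high read-out, while the comparison with the isopropyl amide gives a number 16 percentage points higher from compound 2 to compound 4 (beyond the scatter). Nothing available explains why the read-out stays high after this exchange.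

From the compounds shown here alone, whether the methyl on the ring contributes remains open, since a plain phenyl ring would be needed to separate it from the ring itself. Going by these compounds, it is also open whether a pyridine ring, a small alkyl such as methyl, or a chain ending in a carboxylic acid on the sulfonyl sulfur would stay in the same band.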